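The source may hold more compounds than are shown below. What is called first, only, known or untested is meant among the compounds shown, and "the series" means these compounds.

Compound 1 `CCCCOc1ccc(C(=O)NNc2c(Br)cccc2Br)cc1` was examined in a toxicity assay on MDCK cells (Canis lupus familiaris) for cytotoxicity, read by CCK-8 assay, with a stated time of 48 h; on this read-out higher numbers stand for lower toxicity in this test and lower numbers for higher toxicity in this test. In this assay compound 1 gives > 100000 nM, a limit of the assay rather than a number (the limit of > 100000 nM in this assay, at which 1 of the 2 values shown sits). Compound 2 `CCOc1ccc(C(=O)NNc2c(Br)cc(Br)cc2Br)cc1` gives 54800 nM in this assay. Compound 3 `Nc1ccc(C(=O)NNc2c(Br)cccc2Br)cc1` has not yet been measured; it differs from compound 1 by amino in place of butoxy on an aromatic carbon. For the measured compounds named here, no measured step between compounds that differ in one place exists here, so the size of this change in this assay is open; the expectation is a step of no more than the usual scatter, with no clear direction. Compound 3 is therefore expected to give about 100000 nM, between 40000 nM and 300000 nM, an expected step of a number no higher from compound 1 to compound 3 (the limit leaves the size open) in this assay.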

Compound 3, half-maximal cytotoxic concentration: > 100000 nM
Compound 3: no number, only a limit (the forecaster's own chance of this, stated with the estimate: 60%); the middle value lies on the limit itself.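

No step can be read from compound 1 to compound 3, since both stand at a limit of this assay rather than at a number: the limit of > 100000 nM in this assay, at which 2 of the 3 values shown sit. The compounds shown leave open whether amino in place of butoxy changes the read-out in this assay at all, and by how much.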